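The source may report more compounds than this note shows. Statements on the series, on what has been measured and on what is new or still open speak of the compounds shown alone.

Compound 1, `N#Cc1c(Nc2cccc(Cl)c2)nc(SCc2cn(Cc3ccccc3Cl)nn2)nc1-c1ccccc1`, gives 15800 nM in a functional assay on MGC-803 cells (Homo sapiens) for inhibition, read by MTT assay, with a stated time of 72 h; a higher number here means a weaker inhibitor, a lower number a stronger inhibitor. Compound 2, `Cc1cccc(Nc2nc(SCc3cn(Cc4ccccc4Cl)nn3)nc(-c3ccccc3)c2C#N)c1`, gives 16200 nM in this assay. The step of a 1.0-fold higher number from compound 1 to compound 2 (0.01 log units; within the scatter) corresponds to methyl in place of chloro on an aromatic carbon, a change made at a place meta to a large group.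

Compound 3, `Cc1ccccc1Nc1nc(SCc2cn(Cc3ccc(Cl)cc3)nn2)nc(-c2ccccc2)c1C#N`, reaches only a limit in this assay, recorded as > 64000 nM; this is a limit of the assay and not a number, so its standing rests on (the limit of > 64000 nM in this assay, at which 1 of the 3 values shown sits). The difference between the core of compound 3 and the core of compound 1 is not broken down here.

Compound 4, `Cc1ccc(Cn2cc(CSc3nc(Nc4ccccc4C)c(C#N)c(-c4ccccc4)n3)nn2)cc1`, is not yet measured in this assay. It differs from compound 3 by methyl in place of chloro on an aromatic carbon, a change sitting para to a large group rather than meta, so it is the same kind of change as that from compound 1 to compound 2, not the same one. Because a 1.0-fold higher number from compound 1 to compound 2 (0.01 log units; within the scatter) lies within the scatter, the step that the limit leaves unreadable from compound 3 to compound 4 is expected to be small as well. Compound 4 is therefore expected to sit near 80000 nM, between 30000 nM and 250000 nM, quite possibly again only as a limit.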

Compound 4, half-maximal inhibitory concentration: > 64000 nM
Compound 4: no number, only a limit; the forecaster's own chance of this, stated with the estimate: 70%; the middle value lies beyond the limit too.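

Among these compounds, compound 3 and compound 4 both end at a limit of the assay rather than a number, so no step between them can be read: the limit of > 64000 nM in this assay, at which 2 of the 4 values shown sit. The compounds shown leave open whether going from 4-chlorophenyl to 4-methylphenyl changes the result in this assay at all, and what number either compound would give.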